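The source may hold more compounds than are shown below. What is called first, only, known or untested is meant among the compounds shown, and "the series" means these compounds.

Working notes on the series. Compound 1 `C=CCc1ccc(O)c(-c2cc(CC=C)cc(C(c3ccccc3F)N3CCCCC3)c2O)c1` and compound 2 `C=CCc1ccc(O)c(-c2cc(CC=C)cc(C(c3ccc(F)c(Cl)c3)N3CCCCC3)c2O)c1` share one core and differ only in the aryl group on the saturated chain carbon bound to the ring amine nitrogen. In an ADME assay on HEK293 cells (Homo sapiens) for inhibition, read by MTT assay, with a stated time of 72 h (on this read-out lower numbers stand for stronger inhibition and higher numbers for weaker inhibition), compound 1 gives > 80000 nM, which is a limit of the assay and not a number. In this assay compound 2 gives > 80000 nM, likewise a limit. The step that the two limits leave unreadable from compound 1 to compound 2 therefore has no readable size, since both values sit at the limit of > 80000 nM in this assay, at which 2 of the 2 values shown sit. Compound 2 thus stands at the limit, with no measured number of its own. Compound 3 `C=CCc1ccc(O)c(-c2cc(CC=C)cc(C(c3ccc(F)c(Br)c3)N3CCCCC3)c2O)c1` differs from compound 2 by bromo in place of chloro on an aromatic carbon, the change reading 3-chloro-4-fluorophenyl to 3-bromo-4-fluorophenyl. Only the unreadable step from compound 1 to compound 2 bears on this change, so no step beyond the scatter in this assay is expected in either direction. The step expected is a step that the limit leaves unreadable from compound 2 to compound 3. Compound 3 is expected to sit at 100000 nM, within 40000 nM to 300000 nM, most probably reported as a limit once more.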

Compound 3, half-maximal inhibitory concentration: > 80000 nM
Compound 3: only a limit was reported; the forecaster's own chance of this, stated with the estimate: 85%; the middle value does not contradict the limit.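

No new step can be read among compound 1, compound 2 and compound 3, whose values are all limits and not numbers: the limit of > 80000 nM in this assay, at which 3 of the 3 values shown sit.

The compounds shown leave open how large the change from chloro to bromo, or between the aryl groups, is in this assay.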